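Swapping phenyl for furan-3-yl: what to expect

The compounds below may be only part of what the source reports. "The series", "measured", "known", "first", "only" and "open" are said of these compounds alone.

- Compound 1 `C/C(=N\NC(N)=S)c1ccc2[nH]c(-c3ccccc3)nc2c1`: 32000 nM
- Compound 2 `C/C(=N\NC(N)=S)c1ccc2c(c1)nc(-c1ccccc1)n2C1CCCCC1`: 24000 nM

Both values come from an ADME assay on MDBK cells (Bos taurus) for cytotoxicity, read by MTT assay, with a stated time of 96 h; a higher number here means that more compound is tolerated, a lower number that less compound is tolerated. Only these two compounds have been measured so far, so compound 1 has a single neighbour, and the two numbers sit within the usual scatter of each other.

Compound 3 `C/C(=N\NC(N)=S)c1ccc2[nH]c(-c3ccoc3)nc2c1` has not been measured. It keeps the core of compound 1 but carries furan-3-yl in place of phenyl on an aromatic carbon.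

Within the data shown here, the only measured step is a 1.3-fold lower number from compound 1 to compound 2 (0.12 log units; within the scatter). That change, cyclohexyl in place of hydrogen, sits on an aromatic nitrogen, so it shows how little this number moved at another place on the core. Among the measured compounds shown here, no measured compound tests a change to the phenyl itself, which leaves the size of this step open and calls for a wide range. With no evidence for a shift in either direction, the expectation starts from compound 1 at 32000 nM, and no step beyond the scatter is expected.

The estimated step is a 1.1-fold lower number from compound 1 to compound 3 (0.03 log units; within the scatter).

For compound 3, the expected value is 30000 nM, with an estimated range of 12000 nM to 75000 nM.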

Compound 3, half-maximal cytotoxic concentration: > 100000 nM
Compound 3: only a limit was reported; the forecaster's own chance of this, stated with the estimate: 15%; middle value at least 3.3-fold (0.52 log units) from the limit.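

In this assay, replacing phenyl with furan-3-yl on the aromatic carbon between two ring nitrogen atoms gives an at least 3.1-fold higher number from compound 1 to compound 3 (0.49 log units; beyond the scatter), so a change at this position can move the number beyond the scatter, whereas the cyclohexyl change on the aromatic nitrogen gave a 1.3-fold lower number from compound 1 to compound 2 (0.12 log units; within the scatter). For compound 3, the reported > 100000 nM is a limit and not a number, so the true size of the step stays unknown: the limit of > 100000 nM in this assay, at which 1 of the 3 values shown sits.

Furan-3-yl differs from phenyl in ring size, in its ring oxygen and in carrying a hydrogen-bond acceptor, and this single pair of compounds cannot show which of these differences matters. As far as these compounds go, it remains open whether other groups on this carbon, such as thiophene-3-yl, a pyridine ring or a saturated cyclohexyl ring, would behave like furan-3-yl or like phenyl. From the compounds shown here alone, it is equally open whether furan-3-yl would produce a similar step on the core of compound 2, where cyclohexyl sits on the aromatic nitrogen.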